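Heteroaryl swaps at the piperazine methylene: compound 4

The source may hold more compounds than are shown below. What is called first, only, known or untested is meant among the compounds shown, and "the series" means these compounds.

Measured in an assay on isolated protein for displacement of a labelled ligand from Gonadotropin-releasing hormone receptor (Homo sapiens); a higher number here means a weaker inhibitor, a lower number a stronger inhibitor:
- compound 1 `CCc1nc(C)c(CN2CCN(c3cccc4[nH]c(-c5ccc(C(C)(C)C)cc5)nc34)CC2)o1`: 37 nM
- compound 2 `Cc1nc(CN2CCN(c3cccc4[nH]c(-c5ccc(C(C)(C)C)cc5)nc34)CC2)c(C)s1`: 21 nM
- compound 3 `Cc1n[nH]c(C)c1CN1CCN(c2cccc3[nH]c(-c4ccc(C(C)(C)C)cc4)nc23)CC1`: 68 nM

Compound 3 has the highest number of the three; its gap to compound 1 is within the scatter, while the step from compound 2 to compound 3 is a 3.2-fold higher number from compound 2 to compound 3 (0.51 log units; beyond the scatter), beyond it. The step from compound 1 to compound 3 is a 1.8-fold higher number from compound 1 to compound 3 (0.26 log units; within the scatter) and from compound 1 to compound 2 is a 1.8-fold lower number from compound 1 to compound 2 (0.25 log units; within the scatter).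

Compound 4 `CCc1cc(CN2CCN(c3cccc4[nH]c(-c5ccc(C(C)(C)C)cc5)nc34)CC2)nn1C` differs from compound 3 by 5-ethyl-1-methyl-1H-pyrazol-3-yl in place of 3,5-dimethyl-1H-pyrazol-4-yl on a saturated chain carbon bound to an amine nitrogen in a ring. The measured steps that bear on this are the heteroaryl exchanges at the same place, all of them small or modest and spanning only a narrow band in this assay. Compound 4 is therefore expected to stay inside that band, with at most a modest lowering of the number relative to compound 3, estimated as a 1.7-fold lower number from compound 3 to compound 4 (0.23 log units; within the scatter). The expected value for compound 4 in this assay is 40 nM, with a range of 15 nM to 120 nM.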

Compound 4, half-maximal inhibitory concentration: 43 nM
For compound 4 the middle estimate is 1.1-fold (0.03 log units) below the measured one; the measured number falls inside the stated range.
By their numbers in this assay, from the lowest: compounds 2, 1, 4 and 3 (each within the scatter of the next, the first and the last beyond it).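

In this assay, a 1.6-fold lower number from compound 3 to compound 4 (0.20 log units; within the scatter) shows that the hydrogen-bond donor count of the group on this saturated chain carbon can go from 1 in 3,5-dimethyl-1H-pyrazol-4-yl to 0 in 5-ethyl-1-methyl-1H-pyrazol-3-yl with the step staying within the scatter. The new pyrazole also sits within the scatter of the oxazole group, with a 1.2-fold higher number from compound 1 to compound 4 (0.07 log units; within the scatter). Against the thiazole group, the exchange gives a 2.0-fold higher number from compound 2 to compound 4 (0.31 log units; beyond the scatter), a modest step beyond the scatter, so the 2,5-dimethyl-1,3-thiazol-4-yl group of compound 2 remains separated from both pyrazoles.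

No measurement shown here explains these small differences. Going by these compounds, whether a group of another kind at this place, such as a carboxylic acid or a primary amine on a longer chain, would leave this narrow band remains open.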